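Chain extension of the diamino side chain of compound 3

This account rests on a few compounds, and the source may have more. Where it says the series, first, only, none or still open, it means among the compounds named here.

Measured so far in an assay on HeLa cells for inhibition of sphingosine-1-phosphate transporter SPNS2 (Mus musculus), read by LC-MS, tested at 2 uM; on this read-out higher numbers stand for more inhibition at the one concentration tested (going by the name of the read-out) and lower numbers for less inhibition:
compound 1 `CCCCCCCCCCc1ccc(-c2noc(CN)n2)cc1` gives 62%
compound 2 `CCCCCCCCCCc1ccc(-c2noc(CCCN)n2)cc1` gives 67%
compound 3 `CCCCCCCCCCc1ccc(-c2noc([C@@H](N)CCN)n2)cc1` gives 14%

Compound 3 stands lowest of the three numbers in this assay: compound 1 lies a number 48 percentage points lower from compound 1 to compound 3 (beyond the scatter) and compound 2 lies a number 53 percentage points lower from compound 2 to compound 3 (beyond the scatter), both beyond the scatter. The next compound, compound 4 `CCCCCCCCCCc1ccc(-c2noc([C@@H](N)CCCN)n2)cc1`, differs from compound 3 by aminomethyl in place of amino on a saturated chain carbon, three bonds along the chain from an amine nitrogen and an aromatic carbon.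

Among the compounds with values here, only one measured step resembles this change: the step from compound 1 to compound 2, which also lengthens the amine-bearing chain by one carbon, gave a number 5 percentage points higher from compound 1 to compound 2 (within the scatter), within the scatter. No step is shown for lengthening the chain when the carbon next to the core carries the second amino group, so the comparison is only approximate. The expectation for compound 4 in this assay is therefore a step of a number 6 percentage points higher from compound 3 to compound 4 (within the scatter), no movement beyond the scatter. Compound 4 is estimated at 20%, with a range from 5% to 40%.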

Compound 4, a percentage reported as inhibition, at one concentration (the size of the read-out at that concentration, not a potency): 40%
The estimate for compound 4 lay 20 percentage points below the measured number, and the stated range covers the measured number.
By their numbers in this assay, from the lowest: compound 3; then compound 4; then compounds 1 and 2 (each within the scatter of the next).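

In this assay, the change from 1,3-diaminopropyl to 1,4-diaminobutyl gives a number 26 percentage points higher from compound 3 to compound 4 (beyond the scatter), so chain length matters at this position when the chain carries the second amino group, whereas a number 5 percentage points higher from compound 1 to compound 2 (within the scatter) shows no such effect for the chains without it. The second amino group still carries a cost at the longer chain: a number 27 percentage points lower from compound 2 to compound 4 (beyond the scatter) and a number 22 percentage points lower from compound 1 to compound 4 (beyond the scatter) place the 1,4-diaminobutyl compound below both mono-amine compounds, so the extension recovers only part of the loss seen in a number 53 percentage points lower from compound 2 to compound 3 (beyond the scatter). No supporting evidence explains this dependence on chain length.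

Open, as far as these compounds go, is whether a longer chain such as 1,5-diaminopentyl would raise the number further or lower it. Also open, from the compounds shown here alone, is how the opposite configuration at the amino-bearing carbon would behave on the 1,4-diaminobutyl chain.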